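This account rests on a few compounds, and the source may have more. Where it says the series, first, only, none or still open, it means among the compounds named here.

Compound 1, `Cc1ccc(C(=O)N[C@@H]2C[C@H](C)CC[C@H]2C(C)C)cc1`, gives 2500 nM in a functional assay on HEK293 cells for antagonist activity at transient receptor potential cation channel subfamily M member 8 (Rattus norvegicus), read by calcium flux; on this read-out lower numbers stand for stronger inhibition and higher numbers for weaker inhibition.
Compound 2, `CCCCCCCC/C=C\CCCCCCCCC(=O)N[C@@H]1C[C@H](C)CC[C@H]1C(C)C`, reaches only the limit of > 100000 nM in this assay; this is a limit of the measurement, not a number.
Compound 3, `CC(C)[C@@H]1CC[C@@H](C)C[C@H]1NC(=O)CCCCCCc1ccccc1`, gives 400 nM in this assay.

All three compounds share the same saturated core, and they differ only in the group attached through the amide. Among the two compounds that gave a number, compound 3 stands as the lower one, with compound 1 beyond the scatter above it; the value of compound 2 is a limit and cannot be placed against these two. Of the three values shown, one sits at the limit, namely (the limit of > 100000 nM in this assay, at which 1 of the 3 values shown sits).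

The next compound, compound 4, `CC(C)[C@@H]1CC[C@@H](C)C[C@H]1NC(=O)CCCCCCCc1ccccc1`, has not been measured. It differs from compound 3 in one place: benzyl in place of phenyl on a saturated chain carbon, six bonds along the chain from a carbonyl carbon. The chain that links the amide to the aromatic ring thus grows by a single carbon, and the same difference, cut one bond further out, reads benzyl to phenethyl. For the measured compounds named here, with no measured pair of this kind to compare against, the step is expected to stay small, with no change beyond the scatter in either direction. For compound 4 in this assay the expected value is 350 nM, in a range from 120 nM to 1200 nM, which means an expected step of a 1.1-fold lower number from compound 3 to compound 4 (0.06 log units; within the scatter).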

Compound 4, half-maximal inhibitory concentration: 500 nM
The estimate for compound 4 lay 1.4-fold (0.15 log units) below the measured number; low and high end bracket the measured number.
By their numbers in this assay, from the lowest: compounds 3 and 4 (each within the scatter of the next); then compound 1. At a limit, above all of these: compound 2.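

The change of phenyl to benzyl on a saturated chain carbon, six bonds along the chain from a carbonyl carbon, lengthens the link between the amide and the aromatic ring by a single carbon and gives a 1.3-fold higher number from compound 3 to compound 4 (0.10 log units; within the scatter). For the compounds shown here, this is the first pair that differs in only one place, so it is the first direct reading of what a single change does in this assay, and here the extra carbon leaves no difference that can be told from the scatter, which means compound 3 and compound 4 cannot be put in order. Nothing shown here explains why the number holds steady across this change.

Going by these compounds, a single step cannot show how far this tolerance runs, so it stays open whether phenethyl at the same place, or a still longer chain, would also leave the number unchanged. Also open, on these data alone, is what an amine or a carboxylic acid on the chain, or a fluorine or methoxy group on the aromatic ring, would do to the number.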